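Terminal amine variation in the cytotoxicity series

The source may hold more compounds than are shown below. What is called first, only, known or untested is meant among the compounds shown, and "the series" means these compounds.

Measured compounds:
compound 1 `COc1ccc(-c2cc(=O)c3c(O)cc(OCCCCN4CCN(C)CC4)c(OC)c3o2)cc1`: 3980 nM in a functional assay on MCF7 cells (Homo sapiens) for cytotoxicity, read by MTT assay, with a stated time of 72 h; on this read-out higher numbers stand for weaker inhibition and lower numbers for stronger inhibition
compound 2 `CN(C)CCCOc1c(OCc2ccccc2)cc(O)c2c(=O)cc(-c3ccccc3)oc12`: 3210 nM
compound 3 `CCN(CC)CCCOc1c(OCc2ccccc2)cc(O)c2c(=O)cc(-c3ccccc3)oc12`: 3210 nM

Compound 3 stands level with compound 2 at the digits shown, and all three numbers lie within the scatter of one another, compound 1 being the furthest away. Compound 4 `O=c1cc(-c2ccccc2)oc2c(OCCCN3CCCC3)c(OCc3ccccc3)cc(O)c12` differs from compound 3 by pyrrolidin-1-yl in place of diethylamino on a saturated chain carbon, three bonds along the chain from an oxygen on an aromatic ring. Among the measured compounds shown here, the only measured step on this chain end, no change at the digits printed from compound 2 to compound 3 (within the scatter), was flat. For the measured compounds named here, that is the single step bearing on the change in this assay, and it gives no ground to expect a step beyond the scatter in either direction. For compound 4 a value of 3200 nM is expected, with a range from 1600 nM to 6400 nM. The expected step is therefore a 1.0-fold lower number from compound 3 to compound 4 (0.00 log units; within the scatter).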

Compound 4, half-maximal inhibitory concentration: 2230 nM
Compound 4: the middle estimate sits 1.4-fold (0.16 log units) above what was measured; measured number inside the range.
By their numbers in this assay, from the lowest: compounds 4, 2, 3 and 1 (each within the scatter of the next).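

With pyrrolidin-1-yl on this saturated chain carbon, this assay shows a 1.4-fold lower number from compound 3 to compound 4 (0.16 log units; within the scatter) and a 1.4-fold lower number from compound 2 to compound 4 (0.16 log units; within the scatter). A ring at the chain end, with the same heavy atoms as diethylamino, therefore reads like the two open-chain amines, and none of the three terminal amines on this chain stands beyond the scatter from the others. No measurement at hand bears on why these readings stay so close.
Still open, from the compounds shown here alone, is whether piperidin-1-yl, morpholin-4-yl or a primary amine at this place would keep the number within the scatter. A carboxylic acid in place of the amine is equally untested in the compounds shown.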